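The source may hold more compounds than are shown below. What is called first, only, known or untested is meant among the compounds shown, and "the series" means these compounds.

Of the compounds shown here, three have so far been measured in an ADME assay for permeability, using PAMPA, with a stated time of 30 min, at pH 7.4; a lower number here means that the compound crosses the layer more slowly, a higher number that the compound crosses the layer faster. Compound 1 `COc1cccc(CNCCCNc2ccnc3cc(C4CCCCC4)ccc23)c1O` gives 23 10^-6 cm/s. Compound 2 `CCC(CC)c1ccc2c(NCCCNCc3cc(F)ccc3OC)ccnc2c1` gives 23 10^-6 cm/s, and compound 3 `CCC(CC)c1ccc2c(NCCCNCc3ccco3)ccnc2c1` gives 23 10^-6 cm/s. Compound 2 thus stands level with compound 1 and compound 3 at the digits shown, all three within the scatter of one another. Among the compounds with values here, the single step measured between compounds differing in one place, no change at the digits printed from compound 2 to compound 3 (within the scatter), exchanged one group on the saturated chain carbon bound to an amine nitrogen and left the read-out where it was.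

The step now followed leads from compound 2 to compound 4 `COc1ccc(F)cc1CNCCCNc1ccnc2cc(CC(C)C)ccc12`, which has not yet been measured. The change is isobutyl in place of pentan-3-yl on an aromatic carbon. Within the data shown here, no measured step touches the place of this change, so the guidance is indirect: the three measured values coincide, and the one recorded exchange of a group, no change at the digits printed from compound 2 to compound 3 (within the scatter), produced nothing beyond the scatter. On that basis the expected step of no change at the digits printed from compound 2 to compound 4 (within the scatter) is no change beyond the scatter in this assay, in neither direction. Compound 4 is therefore estimated at 23 10^-6 cm/s, with a range from 12 10^-6 cm/s to 40 10^-6 cm/s to cover the usual variation of the measurement.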

Compound 4, apparent permeability: 23 10^-6 cm/s
For compound 4 middle estimate and measured number coincide at the digits printed, within the range that was stated.
By their numbers in this assay, from the lowest: compounds 1, 2, 3 and 4 (each within the scatter of the next).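

In this assay, within the data shown here, the exchange of pentan-3-yl for isobutyl on an aromatic carbon gives no change at the digits printed from compound 2 to compound 4 (within the scatter), and this is the first measured step at this place, the earlier step having touched only the group on the saturated chain carbon. It shows that at this position, meta to one fused ring and para to the other as printed for this place, a group of 5 heavy atoms can give way to one of 4 without a shift beyond the scatter, with both groups carrying no ring, no hydrogen-bond donors or acceptors and no net charge. Nothing further is available to explain this result, so the step stands as an observation only.

Going by these compounds, both groups at this aromatic carbon are open-chain hydrocarbons with no net charge, so it remains open whether an amine, a carboxylic acid or a longer chain such as octyl in the same place would also leave the read-out within the scatter. Also open, on these data alone, is whether isobutyl at this place and furan-2-yl on the saturated chain carbon, each tested here as a single exchange, would give the same result when combined in one compound.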